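Swapping a fluorinated side chain for an ethylcyclopropyl carbamate

The source may report more compounds than this note shows. Statements on the series, on what has been measured and on what is new or still open speak of the compounds shown alone.

Compound 3 `Cc1nc(S(C)(=O)=O)ccc1Oc1ncnc(OC2CCN(C(=O)O[C@@H](C)CF)CC2)c1F` was tested in a functional assay on isolated protein for inhibition of Glucose-dependent insulinotropic receptor (Rattus norvegicus), read by HTRF and cAMP accumulation (a lower number here means a smaller maximal response, a higher number a larger maximal response), and gave 84%. Among the three measured compounds it stands second highest: compound 1 `Cc1nc(S(C)(=O)=O)ccc1Oc1ncnc(OC2CCN(C(=O)OC(C)C)CC2)c1F` gives 77%, a difference within the usual scatter, while compound 2 `Cc1nc(S(C)(=O)=O)ccc1Oc1ncnc(OC2CCN(C(=O)OC(C)(C)CF)CC2)c1F` gives 95%, and the step of a number 11 percentage points lower from compound 2 to compound 3 (beyond the scatter) lies beyond the scatter. Compound 4 `CCC1(OC(=O)N2CCC(Oc3ncnc(Oc4ccc(S(C)(=O)=O)nc4C)c3F)CC2)CC1` differs from compound 3 in one place: 1-ethylcyclopropyl in place of 1-(fluoromethyl)ethyl on an oxygen next to a carbonyl group. The change restores a fully substituted carbon on that oxygen, as in compound 2, but removes the fluorine. Among the measured compounds shown here, two measured steps bear on this. The step of a number 18 percentage points higher from compound 1 to compound 2 (beyond the scatter) shows that building out this carbon raised the maximal response, and the step of a number 11 percentage points lower from compound 2 to compound 3 (beyond the scatter) shows that trimming it back lowered the response again. Compound 1 and compound 3 differ only by the fluorine, and the step of a number 7 percentage points higher from compound 1 to compound 3 (within the scatter) stays within the scatter, so the fluorine alone seems to matter little. A small rise, a number 4 percentage points higher from compound 3 to compound 4 (within the scatter), is therefore expected, and compound 4 is estimated at 88%, with a likely range from 76% to 98%.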

Compound 4, largest response reached (reported as efficacy), in percent of the reference or control that the assay uses: 83%
The estimate for compound 4 lay 5 percentage points above the measured number; the measured number falls inside the stated range.
By their numbers in this assay, from the lowest: compounds 1, 4 and 3 (each within the scatter of the next); then compound 2.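

In this assay, the step of a number 12 percentage points lower from compound 2 to compound 4 (beyond the scatter) shows that a fully substituted carbon on this oxygen does not by itself give the response of compound 2, since 1-ethylcyclopropyl falls short of 1-(fluoromethyl)-1-methylethyl. The steps of a number 1 percentage points lower from compound 3 to compound 4 (within the scatter) and a number 6 percentage points higher from compound 1 to compound 4 (within the scatter) both stay within the scatter, so at this position 1-ethylcyclopropyl cannot be told apart from either 1-(fluoromethyl)ethyl or isopropyl, despite the added three-membered ring. Nothing measured here explains why compound 2 stands apart from the other three compounds.

As far as these compounds go, it remains open how a tert-butyl group, which has no fluorine, would compare with 1-(fluoromethyl)-1-methylethyl on this oxygen. Also open, from the compounds shown here alone, is how a 1-(fluoromethyl)cyclopropyl group, which joins the ring of compound 4 to the fluorine of compound 2, would respond.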